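Lengthening the Ester Linker in a Sartan-Type Series

The compounds below may be only part of what the source reports. "The series", "measured", "known", "first", "only" and "open" are said of these compounds alone.

Three compounds share one core and differ only in the group attached to the ester. Compound 1 `CCCc1nc(CC)c(C(=O)OCC(=O)c2ccccc2)n1Cc1ccc(-c2ccccc2S(=O)(=O)NC(=O)OCCC(C)C)cc1F` gives in an assay on isolated protein for binding affinity to Type-2 angiotensin II receptor (Homo sapiens) (on this read-out higher numbers stand for weaker inhibition and lower numbers for stronger inhibition), a value of 2 nM. Compound 2 `CCCc1nc(CC)c(C(=O)OCc2ccccc2OCCC(C)C)n1Cc1ccc(-c2ccccc2S(=O)(=O)NC(=O)OCCC(C)C)cc1F` gives 10 nM in this assay, and compound 3 `CCCc1nc(CC)c(C(=O)OCCN2C(=O)c3ccccc3C2=O)n1Cc1ccc(-c2ccccc2S(=O)(=O)NC(=O)OCCC(C)C)cc1F` gives 7 nM. Among these three numbers compound 3 stands second highest: the step of a 3.5-fold higher number from compound 1 to compound 3 (0.54 log units; beyond the scatter) lies beyond the scatter, whereas the step of a 1.4-fold lower number from compound 2 to compound 3 (0.15 log units; within the scatter) does not, so compound 2 and compound 3 cannot be told apart. Compound 4 `CCCc1nc(CC)c(C(=O)OCCCN2C(=O)c3ccccc3C2=O)n1Cc1ccc(-c2ccccc2S(=O)(=O)NC(=O)OCCC(C)C)cc1F` differs from compound 3 by a group of 12 heavy atoms (9 carbon, 1 nitrogen, 2 oxygen; one five-membered non-aromatic ring with 1 hetero atom, one six-membered aromatic ring of carbon only) in place of a group of 11 heavy atoms (8 carbon, 1 nitrogen, 2 oxygen; one five-membered non-aromatic ring with 1 hetero atom, one six-membered aromatic ring of carbon only), on a saturated chain carbon, two bonds along the chain from an oxygen next to a carbonyl group. Within the data shown here, no measured step changes this chain length; the steps that touch the ester side, a 5.0-fold higher number from compound 1 to compound 2 (0.70 log units; beyond the scatter) and a 3.5-fold higher number from compound 1 to compound 3 (0.54 log units; beyond the scatter), were modest, and a 1.4-fold lower number from compound 2 to compound 3 (0.15 log units; within the scatter) was within the scatter. A small step is therefore expected here, a 1.1-fold higher number from compound 3 to compound 4 (0.06 log units; within the scatter), with neither direction clearly favoured. For compound 4 the expected value in this assay is 8 nM, with a range of 3 nM to 25 nM.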

Compound 4, half-maximal inhibitory concentration: 3 nM
Compound 4: the middle estimate sits 2.7-fold (0.43 log units) above what was measured; measured number inside the range.
By their numbers in this assay, from the lowest: compounds 1 and 4 (each within the scatter of the next); then compounds 3 and 2 (each within the scatter of the next).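

Adding one carbon to the saturated chain while keeping the same ring system at its end gives a 2.3-fold lower number from compound 3 to compound 4 (0.37 log units; beyond the scatter) in this assay, a modest change but beyond the scatter. Among these compounds, the earlier steps all replaced the end group itself, so this is the first sign that chain length alone matters at this position. Compound 1 at 2 nM and compound 4 at 3 nM lie within the scatter of each other, though no available evidence explains the effect of the extra carbon.

With only two chain lengths shown, a single step cannot establish a trend, and a longer chain could continue this change, stall or reverse it. Also open, from the compounds shown here alone, is whether this longer chain would have a similar effect with a different end group, such as an amine or a carboxylic acid.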